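This account rests on a few compounds, and the source may have more. Where it says the series, first, only, none or still open, it means among the compounds named here.

Of the compounds shown here, two carrying the same amide-linked core have been tested for their ability to slow the growth of cervical cancer cells. Compound 1 `O=C(Nc1ccc(Cl)c(-c2nnc3c(Cl)cccn23)c1)c1ccc(C(F)(F)F)cc1F` is one of them. In a functional assay on HeLa cells (Homo sapiens) for antiproliferative activity, read by MTT assay, with a stated time of 72 h (a lower number here means a stronger inhibitor, a higher number a weaker inhibitor), compound 1 gives 61900 nM. Compound 2 `O=C(Nc1ccc(Cl)c(-c2nnc3c(Cl)cccn23)c1)c1ccccc1Cl` is the other. For compound 2 this assay reports only a limit, > 100000 nM, rather than a number. Within the pair, then, compound 2 stands at the weak end of what was observed, at the edge of what the assay can resolve, while compound 1 sits below that edge (the limit of > 100000 nM in this assay, at which 1 of the 2 values shown sits).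

The next compound, compound 3 `O=C(Nc1ccc(Cl)c(-c2nnc3c(Cl)cccn23)c1)c1ccc(F)cc1Cl`, departs from compound 2 by one change: fluoro in place of hydrogen on an aromatic carbon. Since the activity of compound 2 is known only as a limit, the step from compound 2 to compound 3 cannot be measured as a number even in principle; the account can only say whether compound 3 is expected to come into the measurable range. A small step toward stronger inhibition is expected, an at least 1.1-fold lower number from compound 2 to compound 3 (0.04 log units; that floor lies within the scatter), with a real chance that compound 3 also ends at the limit. The activity of compound 3 in this assay is estimated at 90000 nM, within a range from 30000 nM to 300000 nM.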

Compound 3, half-maximal inhibitory concentration: > 100000 nM
Compound 3: only a limit was reported (the forecaster's own chance of this, stated with the estimate: 55%); middle value at least 1.1-fold (0.04 log units) from the limit.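

Among the compounds shown here, compound 2 and compound 3 both end at a limit in this assay, so no step between them can be read: the limit of > 100000 nM in this assay, at which 2 of the 3 values shown sit. The compounds shown leave open what the actual activity of compound 2 and compound 3 is, and whether fluoro in place of hydrogen changes it at all.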